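This account rests on a few compounds, and the source may have more. Where it says the series, first, only, none or still open, it means among the compounds named here.

Working notes on the series. The shared core is carried by compound 1 `CNC(=O)c1cc(C(=O)NC2CCC2)cn(Cc2cccnc2)c1=O`, compound 2 `CNC(=O)c1cc(C(=O)NC2CC2)cn(Cc2cccc3cc[nH]c23)c1=O`, compound 3 `CNC(=O)c1cc(C(=O)NCCC(C)C)cn(Cc2ccccc2)c1=O` and the not yet measured compound 4 `CNC(=O)c1cc(C(=O)NC2CC2)cn(Cc2cccc(C#N)c2)c1=O`. In a physicochemical assay for solubility (on this read-out lower numbers stand for lower solubility and higher numbers for higher solubility), compound 2 gives >= 144 ug/mL, which is a limit of the assay rather than a number. In this assay compound 1 likewise gives only a limit, >= 99 ug/mL. In this assay compound 3 gives 10 ug/mL. As far as these compounds go, compound 2 therefore stands at a limit, and one of the two other values shown is a limit as well, so its exact standing among them stays open. From compound 2 to compound 4 the change is 3-cyanophenyl in place of 1H-indol-7-yl on a saturated chain carbon bound to an aromatic nitrogen. For the measured compounds named here, no measured pair differs in one place, so a downward step of modest size in this assay is expected rather than known. For compound 4 the expected value is 60 ug/mL, with a range from 15 ug/mL to 150 ug/mL. The step this estimate implies, an at least 2.4-fold lower number from compound 2 to compound 4 (0.38 log units; beyond the scatter), is an expectation only.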

Compound 4, solubility: >= 148 ug/mL
Compound 4: only a limit was reported (the forecaster's own chance of this, stated with the estimate: 30%); middle value at least 2.4-fold (0.39 log units) from the limit.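

In this assay compound 4 gives >= 148 ug/mL, which is a limit of the assay. For the compounds shown here, compound 2 also stands at a limit, and no step between compound 2 and compound 4 can be read. As far as these compounds go, whether 3-cyanophenyl in place of 1H-indol-7-yl changes the read-out at all stays open.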